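The source may hold more compounds than are shown below. What is called first, only, known or untested is meant among the compounds shown, and "the series" means these compounds.

Working notes on the series, read in a toxicity assay on HUVEC cells (Homo sapiens) for cytotoxicity, read by MTT assay, with a stated time of 96 h; on this read-out higher numbers stand for weaker inhibition and lower numbers for stronger inhibition. Compound 1 (`O=C1NC(=O)/C(=C\c2ccc(OCC(=O)N3N=C(c4ccc(F)cc4)CC3c3ccccc3)cc2)S1`) gives > 10000 nM, which is a limit of the assay and not a number. For the measured compounds named here, compound 2 (`O=C1NC(=O)/C(=C\c2ccc(OCC(=O)N3N=C(c4ccc(F)cc4)CC3c3ccc(C(F)(F)F)cc3)cc2)S1`) gives 6000 nM, the only actual number so far.

Compound 3 (`O=C1NC(=O)/C(=C\c2ccc(OCC(=O)N3N=C(c4ccc(F)cc4)CC3c3ccc(F)cc3)cc2)S1`) carries fluoro in place of trifluoromethyl on an aromatic carbon, the change being 4-(trifluoromethyl)phenyl to 4-fluorophenyl: fluoro in place of trifluoromethyl on an aromatic carbon.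

Going by the values given here, one measured step bears on this, the entry of trifluoromethyl in place of hydrogen at that ring carbon: an at least 1.6-fold lower number from compound 1 to compound 2 (0.22 log units; that floor lies within the scatter). That size is only a floor, and it lies within the scatter, so it fixes neither a true size nor, firmly, a direction. Removing the trifluoromethyl from compound 2 at 6000 nM gave compound 1 when hydrogen entered, so a small move toward a higher number, meaning weaker inhibition, is expected, with no change beyond the scatter. The expected step is a 1.3-fold higher number from compound 2 to compound 3 (0.12 log units; within the scatter). For compound 3 the estimated value is 8000 nM, with an expected range of 4000 nM to 10000 nM.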

Compound 3, half-maximal inhibitory concentration: > 10000 nM
Compound 3 gave a limit, no number; the forecaster's own chance of this, stated with the estimate: 35%; at least 1.2-fold (0.09 log units) between middle value and limit.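

In this assay, exchanging trifluoromethyl for fluoro on this aromatic carbon, para to a large group, gives an at least 1.6-fold higher number from compound 2 to compound 3 (0.22 log units; that floor lies within the scatter), so this second change at the position again yields only a floor within the scatter and fixes no firm direction or true size, while the 4-(trifluoromethyl)phenyl of compound 2 remains the only variant at this position with an actual number. The step between the hydrogen of compound 1 and the fluoro of compound 3 cannot be read, as both values are limits of the assay and not numbers, so these two groups cannot be ordered against each other. What the position can show in this assay is now bounded on the weak side by one assay limit, which leaves a single number in the series and nothing measured to compare it with: the limit of > 10000 nM in this assay, at which 2 of the 3 values shown sit.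

From the compounds shown here alone, whether the 4-(trifluoromethyl)phenyl of compound 2 truly differs from the other two variants therefore stays open, and a repeat reading would need to go beyond the scatter to settle it. Also open, going by these compounds, is how a methoxy, an amine or a carboxylic acid on this same ring carbon would read, and whether any of them would give a number rather than a limit.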